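Adding a second methoxy to the pyrazole aryl ring

The source may hold more compounds than are shown below. What is called first, only, known or untested is meant among the compounds shown, and "the series" means these compounds.

Measured compounds:
compound 1 `COc1ccc(-c2cc(/C=C/C(=O)c3ccc(N)cc3)[nH]n2)cc1` 4920 nM
compound 2 `COc1ccc(C(=O)/C=C/c2cc(-c3cc(OC)c(OC)c(OC)c3)n[nH]2)cc1OC` 3030 nM
compound 3 `COc1cc(-c2cc(/C=C/C(=O)c3ccc(F)c(F)c3)[nH]n2)cc(OC)c1OC` 33800 nM

In a functional assay on OVCAR-5 cells (Homo sapiens) for inhibition, read by sulforhodamine B assay, with a stated time of 48 h (on this read-out lower numbers stand for stronger inhibition of growth and higher numbers for weaker inhibition of growth), compound 1 gives 4920 nM, the second highest of the three numbers; compound 2 lies within the scatter of it, while compound 3 stands well apart. Compound 4 `COc1ccc(-c2cc(/C=C/C(=O)c3ccc(N)cc3)[nH]n2)cc1OC` differs from compound 1 by methoxy in place of hydrogen on an aromatic carbon. Going by the values given here, the only single-point step measured, an 11-fold higher number from compound 2 to compound 3 (1.05 log units; beyond the scatter), concerns the aryl on the carbonyl carbon, not the ring changed here, so it does not bear on this change. Compounds 1 and 2, which carry different numbers of methoxy groups on both rings, give values within the scatter of each other. Compound 4 is therefore expected to show no step beyond the scatter, a 1.2-fold lower number from compound 1 to compound 4 (0.09 log units; within the scatter). Compound 4 is estimated at 4000 nM, within 1500 nM to 12000 nM.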

Compound 4, concentration for total growth inhibition: 7940 nM
Compound 4: middle estimate off by 2.0-fold (0.30 log units), on the low side; measured number inside the range.
By their numbers in this assay, from the lowest: compounds 2, 1 and 4 (each within the scatter of the next, the first and the last beyond it); then compound 3.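

In this assay, going by these compounds alone, methoxy in place of hydrogen on this aromatic carbon, ortho to a methoxy group, gives a 1.6-fold higher number from compound 1 to compound 4 (0.21 log units; within the scatter), the first reading of a single change on this ring. At this position, the added methoxy therefore produces no step beyond the scatter in the core of compound 1. No measurement shown explains the result.

As far as these compounds go, whether a chlorine or a hydroxyl on the same carbon, or an ethoxy group in place of the new methoxy, would read alike remains open. So does whether the added methoxy would behave the same way with a different aryl on the carbonyl carbon.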